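The compounds below may be only part of what the source reports. "The series", "measured", "known", "first", "only" and "open" are said of these compounds alone.

Series notes. Compound 1 `COc1ccc(NC(=O)CCc2cccc3c2B(O)OC3)cc1` and compound 2 `O=C(CCc1cccc2c1B(O)OC2)Nc1cccc(-c2cccc(F)c2)c1` share the same core and differ only in the group carried on the amide nitrogen. In a functional assay on HCT-116 cells (Homo sapiens) for antiproliferative activity, read by MTT assay, with a stated time of 72 h (a lower number here means a stronger inhibitor, a higher number a weaker inhibitor), compound 1 gives 1700 nM, and compound 2 gives 460 nM, the lowest of the two numbers, with its gap to compound 1 beyond the scatter. Compound 3 `N#Cc1cccc(-c2cccc(NC(=O)CCc3cccc4c3B(O)OC4)c2)c1` is not yet measured; against compound 2 the change is cyano in place of fluoro on an aromatic carbon. Among the compounds with values here, no measured pair shows this change, so the step of a 1.1-fold higher number from compound 2 to compound 3 (0.04 log units; within the scatter) is expected to be none beyond the scatter, in either direction. For compound 3 in this assay the estimate is 500 nM, with a range of 200 nM to 1500 nM.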

Compound 3, half-maximal inhibitory concentration: 140 nM
The estimate for compound 3 lay 3.6-fold (0.55 log units) above the measured number; the measured number lies below the stated range.
By their numbers in this assay, from the lowest: compound 3; then compound 2; then compound 1.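

In this assay the change from 3-fluorophenyl to 3-cyanophenyl gives a 3.3-fold lower number from compound 2 to compound 3 (0.52 log units; beyond the scatter) with all else held fixed, so this position on the outer aromatic ring, meta to a large group, responds to a single substituent change. The earlier compounds shown here held no pair differing here alone, and this one pair sets no trend. No measurement at hand explains the lower number for compound 3.

From the compounds shown here alone, whether an amine or a carboxylic acid at this position would match the nitrile remains open, as does the effect of moving the nitrile elsewhere on this ring.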